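This account rests on a few compounds, and the source may have more. Where it says the series, first, only, none or still open, it means among the compounds named here.

Measured compounds, in an assay on HEK293 cells for agonist activity at transient receptor potential cation channel subfamily M member 8 (Homo sapiens), read by fluorescence and calcium flux, with a stated time of 15 min; a lower number here means that less compound is needed, a higher number that more compound is needed for the effect:
compound 1, `Cc1ccc(OCC(=O)N(Cc2cccs2)c2c(C)n[nH]c2C)cc1`, gives 0.3 nM;
compound 2, `Cc1ccc(OCC(=O)N(Cc2cccs2)c2ccon2)cc1`, gives 2 nM.

For the measured compounds named here, compound 2 holds the higher of the two numbers so far, and the one measured step, a 6.7-fold higher number from compound 1 to compound 2 (0.82 log units; beyond the scatter), separates it from compound 1. Going by the values given here, that step exchanged one five-membered aromatic ring for another on the amide-type nitrogen, and it was the only change between the two.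

Compound 3, `Cc1ccc(OCC(=O)N(Cc2cccs2)c2nccs2)cc1`, has not yet been measured in this assay. It differs from compound 2 in a single place: 1,3-thiazol-2-yl in place of 1,2-oxazol-3-yl on an amide-type nitrogen. Among the compounds with values here, the step from compound 1 to compound 2 is the only measured comparison that touches this position, and it swapped a different pair of rings, so it bears on the present change only loosely. It shows that a ring exchange at this nitrogen can move the number by a modest amount; it does not say in which direction a further exchange would move it. A step of no more than modest size is therefore expected, with no clear direction beyond the scatter. Compound 3 is estimated to give 1.5 nM in this assay, with a range of 0.4 nM to 6 nM. The expected step is a 1.3-fold lower number from compound 2 to compound 3 (0.12 log units; within the scatter).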

Compound 3, half-maximal effective concentration: 2240 nM
Compound 3: the middle estimate sits 1500-fold (3.17 log units) below what was measured; the whole stated range lies below it.
By their numbers in this assay, from the lowest: compound 1; then compound 2; then compound 3.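

In this assay, the exchange on the amide-type nitrogen gives a 1100-fold higher number from compound 2 to compound 3 (3.05 log units; beyond the scatter), a far larger move than a 6.7-fold higher number from compound 1 to compound 2 (0.82 log units; beyond the scatter) that was the only earlier measure of this position. So this position can respond much more sharply to a ring exchange than the first step showed. The change is also narrower than its size might suggest: 1,2-oxazol-3-yl and 1,3-thiazol-2-yl are both five-membered aromatic rings with the same counts of heavy atoms, hydrogen-bond donors and hydrogen-bond acceptors, with sulfur entering and oxygen leaving, so these counts do not track the result. Measured against the 3,5-dimethyl-1H-pyrazol-4-yl group, the same ring gives a 7500-fold higher number from compound 1 to compound 3 (3.87 log units; beyond the scatter), and nothing available explains why this position tolerates one ring so much less well than the other two.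

The compounds shown do not separate the exchange of oxygen for sulfur from the altered arrangement of the ring atoms, a question that 1,3-oxazol-2-yl or 1,2-thiazol-3-yl on the same nitrogen would address. They also leave open how a plain phenyl ring or a 1H-imidazol-2-yl group would fare at this position.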